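Shortening the Chain and Dropping the Nitrile from Compound 2

This account rests on a few compounds, and the source may have more. Where it says the series, first, only, none or still open, it means among the compounds named here.

Of the compounds shown here, three have been measured in an assay on isolated protein for binding affinity to leukotriene B4 receptor 1 (Homo sapiens), tested at 1 uM; on this read-out lower numbers stand for less inhibition and higher numbers for more inhibition at the one concentration tested (going by the name of the read-out). Compound 2, `C=CCc1cc(C(C)=O)c(O)cc1OCCCCCCCC#N`, gives 52%, the highest of the three numbers. Compound 1, `CC(=O)c1cc(C)c(OCCCCC#N)cc1O`, gives 35%, which lies beyond the scatter below compound 2. Compound 3, `CC(=O)c1cc(C(C)(C)C)c(OCCCCCC(C)(C)C#N)cc1O`, gives 2%, the furthest from compound 2 and likewise beyond the scatter. Within the data shown here, none of these pairs differ in a single place, so the values show only that compound 2 stands above both of the others.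

Compound 4, `C#CCCCCOc1cc(O)c(C(C)=O)cc1CC=C`, is not yet measured. It differs from compound 2 by ethynyl in place of 3-cyanopropyl on a saturated chain carbon, four bonds along the chain from an oxygen on an aromatic ring. The chain on the ring oxygen thus becomes shorter and the nitrile is gone, while the triple bond outside aromatic rings is kept.

Because compound 1, which also carries a shorter chain on that oxygen, gives 35%, a lower number than compound 2 is expected for compound 4. The step of a number 22 percentage points lower from compound 2 to compound 4 (beyond the scatter) is expected to be a moderate loss, beyond the scatter. Compound 4 is therefore estimated at 30% in this assay, with a range from 10% to 50%.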

Compound 4, a percentage reported as inhibition, at one concentration (the size of the read-out at that concentration, not a potency): 29%
Estimate against measurement, compound 4: 1 percentage points above; measured number inside the range.
By their numbers in this assay, from the lowest: compound 3; then compounds 4 and 1 (each within the scatter of the next); then compound 2.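

In this assay, among these compounds, putting ethynyl in place of 3-cyanopropyl on a saturated chain carbon, four bonds along the chain from an oxygen on an aromatic ring, gives a number 23 percentage points lower from compound 2 to compound 4 (beyond the scatter) and is the first change in this set that can be read at a single place. The step shows that the number responds to what is carried at this place on the chain, yet compound 4 still gives 29% at the one concentration tested, so in this pair the inhibition does not vanish when the nitrile goes and the triple bond stays. No measurement on hand explains the fall in the number.

The step changes the length of the chain and removes the nitrile together, and the compounds shown cannot tell how much of the fall belongs to each. Also open, as far as these compounds go, is how this same place on the chain would respond to a longer chain ending in ethynyl, or to a carboxylic acid or an amine at the end of the chain on the shared core.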